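A few compounds are considered here, and "the series" means these few. Any claim that something is new, unique, unknown or untested is made for them only; others in the source may bear on it.

Measured in an assay on membranes from brain for displacement of a labelled ligand from Neuronal acetylcholine receptor; alpha4/beta2 (Rattus norvegicus); on this read-out higher numbers stand for weaker inhibition and lower numbers for stronger inhibition:
Compound 1, `CCCOc1cncc(N2C[C@H]3CNC[C@H]3C2)c1`, gives 0.041 nM.
Compound 2, `Cc1ccc(-c2ccc(N3C[C@H]4CN(C)C[C@H]4C3)nn2)cc1`, yields only a limit of this assay, > 100000 nM.
Compound 3, `CN1C[C@@H]2CN(c3ccc(-c4cccc(-c5ccccc5)c4)nc3)C[C@@H]2C1`, gives 9800 nM.

Compound 2 therefore stands at the weak end of what this assay can report: its result is a limit and not a number, as recorded in the limit of > 100000 nM in this assay, at which 1 of the 3 values shown sits. Compound 4, `Cc1ccccc1-c1ccc(N2C[C@H]3CN(C)C[C@H]3C2)nn1`, is built from the same atoms as compound 2, joined differently: 2-methylphenyl in place of 4-methylphenyl on an aromatic carbon. The change moves a single methyl group within the aryl ring attached to the shared core; nothing is added or removed.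

Among the compounds with values here, no pair of measured compounds differs in exactly this way, so the size of the step can only be expected, not read. Compound 3, which carries a different aryl group on a related core, gives 9800 nM, so both compounds with a bulky aryl substituent in this position sit far from compound 1. Nothing in the data points to the shift of one methyl group moving compound 4 beyond the scatter of this assay relative to compound 2. Compound 4 is accordingly expected to remain very weak in this assay, near 80000 nM, with a plausible range from 10000 nM to 500000 nM. The expected step from compound 2 to compound 4 is thus about an at least 1.2-fold lower number from compound 2 to compound 4 (0.09 log units; that floor lies within the scatter), and a second limit rather than a number is the likelier outcome.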

Compound 4, inhibition constant: > 10000 nM
Compound 4: no number, only a limit; the forecaster's own chance of this, stated with the estimate: 60%; the middle value does not contradict the limit.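

In this assay compound 4 gives only a limit, > 10000 nM. Within the data shown here, compound 2 likewise gives only a limit, > 100000 nM, so no step between compound 2 and compound 4 can be read. The compounds shown leave open whether 2-methylphenyl and 4-methylphenyl on the shared core differ at all in this assay.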